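Methoxy to bromo in an antiproliferative series

The compounds below may be only part of what the source reports. "The series", "measured", "known", "first", "only" and "open" are said of these compounds alone.

Values in a functional assay on HepG2 cells (Homo sapiens) for antiproliferative activity, read by MTT assay, with a stated time of 24 h (on this read-out lower numbers stand for stronger inhibition and higher numbers for weaker inhibition), stand as follows:
Compound 1 `Cc1ccc(-c2nn(-c3ccccc3)cc2-c2nc3ccccc3n2S(=O)(=O)c2ccc(Cl)cc2)cc1` gives 5520 nM
Compound 2 `Cc1ccc(-c2nn(-c3ccccc3)cc2-c2nc3ccccc3n2S(=O)(=O)c2ccc(C(F)(F)F)cc2)cc1` gives 1930 nM
Compound 3 `COc1ccc(S(=O)(=O)n2c(-c3cn(-c4ccccc4)nc3-c3ccc(F)cc3)nc3ccccc32)cc1` gives 470 nM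

Compound 3 holds the lowest number of the three, beyond the scatter against both others. Compound 4 `O=S(=O)(c1ccc(Br)cc1)n1c(-c2cn(-c3ccccc3)nc2-c2ccc(F)cc2)nc2ccccc21` is still unmeasured and differs from it by bromo in place of methoxy on an aromatic carbon, with bromo in place of methoxy on an aromatic carbon. Among the compounds with values here, no measured step exchanges these two groups. The closest evidence is a 2.9-fold lower number from compound 1 to compound 2 (0.46 log units; beyond the scatter), with trifluoromethyl in place of chloro on an aromatic carbon. Compound 1 carries chloro and gives 5520 nM but also differs from compound 3 elsewhere, so only a modest rise is expected in this assay. The expected step runs a 2.1-fold higher number from compound 3 to compound 4 (0.33 log units; beyond the scatter) in this estimate. Compound 4 is estimated at 1000 nM with an expected range from 300 nM to 3500 nM for its measurement.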

Compound 4, half-maximal inhibitory concentration: 2550 nM
Estimate against measurement, compound 4: 2.6-fold (0.41 log units) below; the measured number falls inside the stated range.
By their numbers in this assay, from the lowest: compound 3; then compounds 2 and 4 (each within the scatter of the next); then compound 1.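

In this assay the change from (4-methoxyphenyl)sulfonyl to (4-bromophenyl)sulfonyl gives a 5.4-fold higher number from compound 3 to compound 4 (0.73 log units; beyond the scatter) with the rest of the molecule unchanged. Within the data shown here, this isolates the exchange of methoxy for bromo at this position, which the earlier compounds could not do, and shows that the choice between these two groups alone moves the number beyond the scatter. Nothing measured here accounts for the step.

The compounds shown leave open how an amine or a carboxylic acid would read at this position. They also leave open whether the same exchange would give a similar step on the core of compound 1.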